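Carbamate series: hydrogen in place of aromatic methyl

The source may report more compounds than this note shows. Statements on the series, on what has been measured and on what is new or still open speak of the compounds shown alone.

Three members of the series have been run in a functional assay on MDA-MB-231 cells (Homo sapiens) for antiproliferative activity, read by MTT assay, with a stated time of 96 h; a higher number here means a weaker inhibitor, a lower number a stronger inhibitor. Compound 1 `CC(C)=CCC/C(C)=C/CC/C(C)=C/CC[C@]1(C)CCc2cc(OC(=O)NS(=O)(=O)c3ccc(Cl)cc3)cc(C)c2O1` reaches only the limit of the assay: in this assay compound 1 gives > 10000 nM, a limit rather than a number. Compound 2 `CC(C)=CCC/C(C)=C/CC/C(C)=C/CC[C@]1(C)CCc2cc(OC(=O)Nc3ccccc3)c(C)c(C)c2O1` likewise stands at a limit, giving > 10000 nM in this assay. Compound 3 `CC(C)=CCC/C(C)=C/CC/C(C)=C/CC[C@]1(C)CCc2cc(OC(=O)NS(=O)(=O)c3ccc(C)cc3)c(C)c(C)c2O1` also sits at a limit, with > 10000 nM in this assay. Within the data shown here, the one step measured inside the series, a step that the two limits leave unreadable from compound 2 to compound 3, is therefore of unreadable size, and the shared position of all three is summed up by the limit of > 10000 nM in this assay, at which 3 of the 3 values shown sit.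

Compound 4 `CC(C)=CCC/C(C)=C/CC/C(C)=C/CC[C@]1(C)CCc2cc(OC(=O)Nc3ccccc3)cc(C)c2O1` has not yet been measured. It differs from compound 2 by hydrogen in place of methyl on an aromatic carbon. Among the measured compounds shown here, no measured step covers this change: the only recorded step exchanges the group on the amide-type nitrogen and is unreadable, while compound 1 carries the same hydrogen in place of methyl as compound 4 but differs at the nitrogen, so no pair isolates the aromatic methyl. With every measured value at the limit, no direction can be read for compound 4, and the step expected from the change, a step that the limit leaves unreadable from compound 2 to compound 4, is set at nothing beyond the scatter. For compound 4 the expected value in this assay is 15000 nM, with a range from 5000 nM to 50000 nM, and most likely it will again be reported only as a limit.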

Compound 4, half-maximal inhibitory concentration: > 10000 nM
Compound 4 was reported as a limit; the forecaster's own chance of this, stated with the estimate: 80%; the middle value lies beyond the limit too.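

Compound 4 gives > 10000 nM in this assay, a limit and not a number. Its steps from compound 1 and compound 2 cannot be read, because the series stands entirely at a limit: the limit of > 10000 nM in this assay, at which 4 of the 4 values shown sit.

Still open, going by these compounds, is whether hydrogen in place of methyl on an aromatic carbon, or any exchange on the amide-type nitrogen, alters activity.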